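The compounds below may be only part of what the source reports. "The series", "measured", "known", "first", "only" and "open" are said of these compounds alone.

In a functional assay on HeLa cells (Homo sapiens) for antiproliferative activity, read by MTT assay, with a stated time of 48 h (a lower number here means a stronger inhibitor, a higher number a weaker inhibitor), compound 1 `Cn1c(N)c(-c2nc3ccccc3[nH]2)c2nc(C#N)c(C#N)nc21` gives only a limit, > 50000 nM. Compound 2 `CCN(CC)CCn1c(N)c(-c2nc3ccccc3[nH]2)c2nc(C#N)c(C#N)nc21` gives a measured value of 11600 nM. Compound 3 `N#Cc1nc2c(-c3nc4ccccc4[nH]3)c(N)n(CCN3CCCC3)c2nc1C#N` also gives only a limit, > 50000 nM, and so stands at the limit of > 50000 nM in this assay, at which 2 of the 3 values shown sit.

Compound 4 `CN1CCN(CCn2c(N)c(-c3nc4ccccc4[nH]3)c3nc(C#N)c(C#N)nc32)CC1` differs from compound 3 as follows: 4-methylpiperazin-1-yl in place of pyrrolidin-1-yl on a saturated chain carbon, two bonds along the chain from an aromatic nitrogen. This places 4-methylpiperazin-1-yl in place of pyrrolidin-1-yl on a saturated chain carbon, two bonds along the chain from an aromatic nitrogen.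

For the measured compounds named here, the closest precedent is the change of group at this same place, an at least 4.3-fold higher number from compound 2 to compound 3 (0.63 log units; beyond the scatter), which lies beyond the scatter. The extension of the chain in an at least 4.3-fold lower number from compound 1 to compound 2 (0.63 log units; beyond the scatter) also lies beyond the scatter, whereas a step that the two limits leave unreadable from compound 1 to compound 3 has no readable size. From the compounds shown here alone, with only these compounds, the effect of the group at this place remains open, and compound 4 may also return only a limit. A modest move towards a lower number is expected, no larger than the size seen for compound 2 at 11600 nM.

The estimated value for compound 4 is 30000 nM, with an expected range of 9000 nM to 70000 nM. The expected change is an at least 1.6-fold lower number from compound 3 to compound 4 (0.22 log units; that floor lies within the scatter).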

Compound 4, half-maximal inhibitory concentration: > 50000 nM
Compound 4: a limit, no number; the forecaster's own chance of this, stated with the estimate: 45%; at least 1.6-fold (0.22 log units) between middle value and limit.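

In this assay compound 4 gives only a limit, which places it with compound 1 and compound 3: the limit of > 50000 nM in this assay, at which 3 of the 4 values shown sit. Putting 4-methylpiperazin-1-yl in place of diethylamino gives an at least 4.3-fold higher number from compound 2 to compound 4 (0.63 log units; beyond the scatter), so of the three amines shown on this chain carbon, only diethylamino gives a measured value, and neither ring amine does. The steps from compound 3 to compound 4 and from compound 1 to compound 4 join two limits and cannot be read.

Any difference among compound 1, compound 3 and compound 4 therefore stays hidden behind the limit. From the compounds shown here alone, it also remains open whether another open-chain amine at this place, such as dimethylamino or dipropylamino, or a longer chain carrying diethylamino, would keep a measurable value like that of compound 2.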